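The compounds below may be only part of what the source reports. "The series", "measured", "known", "first", "only" and "open" are said of these compounds alone.

Working notes on the series. Three compounds share one core and differ only in the group on the aromatic carbon of the five-membered ring. Compound 1 `CSc1cccc(Nc2nc(-c3ccc(C#N)cc3)cs2)c1` in an assay on CFBE41o cells for positive allosteric modulation of Cystic fibrosis transmembrane conductance regulator variant F508del (Homo sapiens), with stated times of 30 min and 24 h (a lower number here means that less compound is needed, a higher number that more compound is needed for the effect), gives 34000 nM. Compound 2 `CSc1cccc(Nc2nc(-c3cccc(Cl)c3)cs2)c1` in this assay gives 53000 nM. Compound 3 `CSc1cccc(Nc2nc(-c3ccc4[nH]c(=O)oc4c3)cs2)c1` in this assay gives 6400 nM. Compound 2 stands at the highest number of the three; its nearest neighbour is compound 1, a gap that lies within the scatter, so no order between compound 2 and compound 1 is read from it; compound 3 lies clearly lower, beyond the scatter.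

Compound 4 `CSc1cccc(Nc2nc(-c3nccs3)cs2)c1` is not yet measured. Relative to compound 2 the change is 1,3-thiazol-2-yl in place of 3-chlorophenyl on an aromatic carbon, placed on an aromatic carbon of a five-membered aromatic ring with 1 nitrogen and 1 sulfur; next to the ring nitrogen; two ring bonds from the ring sulfur; two ring bonds from the ring atom that bears a group of 9 heavy atoms. Among the measured compounds shown here, no measured pair shows this exchange, so its step size has no precedent. The step from compound 2 to compound 4 is expected to be modest, a 1.1-fold higher number from compound 2 to compound 4 (0.05 log units; within the scatter), with no direction claimed beyond the scatter. Compound 4 is estimated at 60000 nM, with a range from 20000 nM to 180000 nM.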

Compound 4, half-maximal effective concentration: 9500 nM
Estimate against measurement, compound 4: 6.3-fold (0.80 log units) above, and the stated range ends above it.
By their numbers in this assay, from the lowest: compounds 3 and 4 (each within the scatter of the next); then compounds 1 and 2 (each within the scatter of the next).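

In this assay, among the compounds shown here, the exchange of 3-chlorophenyl for 1,3-thiazol-2-yl gives a 5.6-fold lower number from compound 2 to compound 4 (0.75 log units; beyond the scatter) and is the first step at this position to be read directly from a measured pair, showing that the number here can move beyond the scatter with a single change of group. With this exchange, 7 heavy atoms leave and 5 enter, and the entering ring has 2 hydrogen-bond acceptors where the leaving ring has 0; compound 4 now lies within the scatter of compound 3, while compound 1 and compound 2 form the other pair, so a group need not be a six-membered ring of carbon only to reach the lower pair. No measurement on hand accounts for the step, and this one exchange does not separate the change in ring size from the change in ring atoms or the departure of the chlorine.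

What the ring nitrogen and the ring sulfur each contribute stays open, with 1,3-thiazol-2-yl the only five-membered group at this position among the compounds shown. Thiophen-2-yl and 1,3-oxazol-2-yl at the same carbon, and an unsubstituted phenyl as a reference for compound 2, would separate these contributions.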